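The source may hold more compounds than are shown below. What is called first, only, known or untested is meant among the compounds shown, and "the series" means these compounds.

Values in a functional assay on HEp-2 cells (Homo sapiens) for inhibition (on this read-out higher numbers stand for an effect only at larger amounts of compound and lower numbers for an effect already at smaller amounts), so far:

Compound 1 `CSc1ncnc2[nH]nnc12` with > 300 uM as a limit of the assay
Compound 2 `CSc1ncnc2nn([C@@H]3O[C@H](COC(C)=O)[C@@H](OC(C)=O)[C@H]3OC(C)=O)nc12` with 7 uM as measured
Compound 3 `CSc1ncnc2c1nnn2[C@@H]1O[C@H](CO)[C@@H](O)[C@H]1O` with 0.02 uM as measured

Compound 3 holds the lowest number shown, and its gap to compound 2 lies beyond the scatter. Compound 4 `CCOc1ncnc2c1nnn2[C@@H]1O[C@H](CO)[C@@H](O)[C@H]1O` differs from compound 3 in one place, with ethoxy in place of methylsulfanyl on an aromatic carbon and the rest unchanged. For the measured compounds named here, no measured pair shows this swap, so what follows is a judgement. Since compound 3 at 0.02 uM sits so low, a rise in the number beyond the scatter is expected in this assay rather than a further fall. The estimated change runs a 150-fold higher number from compound 3 to compound 4 (2.18 log units; beyond the scatter) and carries wide uncertainty. The expected value for compound 4 is 3 uM, in an estimated range of 0.15 uM to 60 uM.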

Compound 4, concentration for half-maximal effect: 0.1 uM
Compound 4: the middle estimate sits 30-fold (1.48 log units) above what was measured; the measured number lies below the stated range.
By their numbers in this assay, from the lowest: compound 3; then compound 4; then compound 2. At a limit, above all of these: compound 1.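

Replacing methylsulfanyl with ethoxy on this aromatic carbon keeps the effect at small amounts of compound in this assay, though it gives a 5.0-fold higher number from compound 3 to compound 4 (0.70 log units; beyond the scatter) for this single change. For the compounds shown here, this is the first view of how a change at this position alters the read-out with the rest of the structure held constant. Nothing available on the compounds' properties accounts for this step.

On these data alone, the swap changes both the linking atom and the chain, so their separate contributions remain open. An amine or a longer chain such as butoxy at this carbon would test how far the position tolerates change.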